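The compounds below may be only part of what the source reports. "The series", "measured", "known", "first", "only" and "open" are said of these compounds alone.

In a functional assay on MT4 cells (Homo sapiens) for cytotoxicity (a higher number here means that more compound is tolerated, a lower number that less compound is tolerated), compound 1 (`CCc1c(O)nc(SCC(=O)c2ccc(OC)cc2)nc1Cc1cccc2ccccc12`) gives 178000 nM, and compound 2 (`CCc1c(O)nc(SCC(=O)c2ccc(Cl)cc2)nc1Cc1cccc2ccccc12`) gives 56000 nM, the lower of these two numbers. Compound 3 (`CCc1c(O)nc(SCC(=O)OC)nc1Cc1cccc2ccccc12`) gives >= 196000 nM, which is a limit of the assay and not a number. Compound 4 (`CC(C)c1c(O)nc(SCC(=O)c2ccc(Cl)cc2)nc1Cc1cccc2ccccc12`) differs from compound 2 in one place, with ethyl changed to isopropyl: methyl in place of hydrogen on a saturated chain carbon bound to an aromatic carbon and a saturated chain carbon. For the measured compounds named here, no measured step touches this chain. The closest guides are changes made elsewhere, a 3.2-fold lower number from compound 1 to compound 2 (0.50 log units; beyond the scatter) and an at least 3.5-fold higher number from compound 2 to compound 3 (0.54 log units; beyond the scatter), and they show only how large a step can be in this small set. No clear step beyond the scatter is expected, and the estimated step is a 1.2-fold lower number from compound 2 to compound 4 (0.08 log units; within the scatter). Compound 4 is expected near 47000 nM, within an estimated range of 19000 nM to 115000 nM.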

Compound 4, half-maximal cytotoxic concentration: > 270000 nM
Compound 4 was reported as a limit; the forecaster's own chance of this, stated with the estimate: 7%; middle value at least 5.7-fold (0.75 log units) from the limit.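

In this assay, for the compounds shown here, the change from ethyl to isopropyl gives an at least 4.8-fold higher number from compound 2 to compound 4 (0.68 log units; beyond the scatter), so this chain, untouched by the earlier steps, can by itself shift the number beyond the scatter. Compound 4 gives > 270000 nM, which is a limit of the assay and not a number, so the full size of the step stays unknown: the limit of > 270000 nM in this assay, at which 1 of the 4 values shown sits.

From the compounds shown here alone, whether a longer chain such as butyl, or an amine, would shift the number in the same way remains open. This single pair carries 4-chlorophenyl, so it also leaves open whether isopropyl would do the same alongside 4-methoxyphenyl.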